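The source may hold more compounds than are shown below. What is called first, only, known or untested is meant among the compounds shown, and "the series" means these compounds.

Measured compounds:

Compound 1 `Cc1cc(N2C(=O)CSC2c2c(Cl)cccc2Cl)no1`: 40.5 ug/mL
Compound 2 `Cc1cc(N2C(=O)CSC2c2c(F)cccc2Cl)no1`: 38.5 ug/mL
Compound 3 `Cc1cc(N2C(=O)CSC2c2c(Cl)cccc2Cl)nc(C)c1Br`: 2.5 ug/mL

These three were tested in an ADME assay on TZM cells (Homo sapiens) for cytotoxicity, read by MTT assay, with a stated time of 48 h; on this read-out higher numbers stand for lower toxicity in this test and lower numbers for higher toxicity in this test. Compound 1 and compound 2 differ in one place: fluoro in place of chloro on an aromatic carbon. That change gave a 1.1-fold lower number from compound 1 to compound 2 (0.02 log units; within the scatter), so the two numbers show no real difference. Compound 3 differs from compound 1 in more than one place, and the difference between the two cores is not broken down here; in this assay compound 3 sits furthest from the others, with numbers for compound 1 and compound 2 beyond the scatter above it.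

Compound 4 `Cc1cc(N2C(=O)CSC2c2c(F)cccc2Cl)nc(C)c1Br` has not yet been measured. It stands to compound 3 as compound 2 stands to compound 1: fluoro in place of chloro on an aromatic carbon. The place is described in the same words for both pairs, so this is the same change. The step from compound 3 to compound 4 is expected to be small, a 1.0-fold lower number from compound 3 to compound 4 (0.02 log units; within the scatter), because a 1.1-fold lower number from compound 1 to compound 2 (0.02 log units; within the scatter) stayed within the scatter. Compound 4 is therefore estimated at 2.4 ug/mL, with a likely range of 1.2 ug/mL to 5 ug/mL.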

Compound 4, half-maximal cytotoxic concentration: 40.2 ug/mL
Estimate against measurement, compound 4: 17-fold (1.22 log units) below, outside the stated range (above it).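

In this assay, fluoro in place of chloro on an aromatic carbon gave a 16-fold higher number from compound 3 to compound 4 (1.21 log units; beyond the scatter), which points to lower toxicity in this test for the fluoro compound on this core. The same change therefore did not carry over from one core to the other, and the step seen on the first core was a poor guide to the step on the second: the same change on two cores in this assay, a 1.1-fold lower number (0.02 log units; within the scatter) from compound 1 to compound 2 and a 16-fold higher number (1.21 log units; beyond the scatter) from compound 3 to compound 4, 17-fold (1.23 log units) apart, beyond the scatter of two such steps

This rests on a single pair on each core. It does not show which of the several differences between the two cores is responsible, nor how the change would behave on any further core.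

The compounds shown carry only chloro or fluoro at this place, so it stays open whether a methyl or a methoxy group there would also give steps that differ between the two cores. Also open, on these data alone, is whether the bromo group alone, without the other differences in the core of compound 3, would be enough to make the step differ.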